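Swapping a Four-Carbon Ring for a Three-Carbon Ring

The source may report more compounds than this note shows. Statements on the series, on what has been measured and on what is new or still open speak of the compounds shown alone.

Of the compounds shown here, two have numbers so far. Compound 1 `CCC1(O)CCN(c2nc(C)c3cc(NC(=O)COc4ccc(Cl)cc4)ccc3n2)CC1` gives 208 nM in an assay on CHO-K1 cells for displacement of a labelled ligand from melanin-concentrating hormone receptor 1 (Homo sapiens), with a stated time of 2 h; on this read-out lower numbers stand for stronger inhibition and higher numbers for weaker inhibition. Compound 2 `Cc1nc(N2CCN(C(=O)C3CCC3)CC2)nc2ccc(NC(=O)COc3ccc(OC(F)(F)F)cc3)cc12` gives 84 nM in this assay, the lowest of the two numbers, and its gap to compound 1 lies beyond the usual scatter. Compound 3 `Cc1nc(N2CCN(C(=O)C3CC3)CC2)nc2ccc(NC(=O)COc3ccc(OC(F)(F)F)cc3)cc12` differs from compound 2 in one place: cyclopropyl in place of cyclobutyl on a carbonyl carbon. Going by the values given here, no measured pair shows what this change does, so the expected step from compound 2 to compound 3 in this assay is small, a 1.1-fold higher number from compound 2 to compound 3 (0.03 log units; within the scatter), in no clear direction beyond the scatter. Compound 3 is therefore estimated at 90 nM, within a range of 40 nM to 200 nM.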

Compound 3, half-maximal inhibitory concentration in the melanin-concentrating hormone receptor 1 assay: 49 nM
Compound 3: middle estimate off by 1.8-fold (0.26 log units), on the high side, and the stated range covers the measured number.
By their numbers in the melanin-concentrating hormone receptor 1 assay, from the lowest: compounds 3 and 2 (each within the scatter of the next); then compound 1.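

In the melanin-concentrating hormone receptor 1 assay, cyclopropyl in place of cyclobutyl on the carbonyl carbon gives a 1.7-fold lower number from compound 2 to compound 3 (0.23 log units; within the scatter), so this position accepts either ring without a change that can be told from the scatter. In a physicochemical assay for solubility, in phosphate buffer (on this read-out lower numbers stand for lower solubility and higher numbers for higher solubility), compound 2 gives 4000 nM and compound 3 gives 8000 nM, a pair that also stays within the scatter. Nothing available here accounts for these numbers.

The compounds shown leave open how this carbonyl would read in either assay with a group that has no ring, such as a methyl group or a dimethylamine.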